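Swapping the Cyclohexylmethyl Chain for a Carbamoyl Cyclobutyl

This account rests on a few compounds, and the source may have more. Where it says the series, first, only, none or still open, it means among the compounds named here.

Two measured compounds share one core. Compound 1 `N#Cc1cnc(NCc2ccccc2C(F)(F)F)cc1N[C@H]1CC[C@@H](O)CC1` gives in an assay on isolated protein for inhibition of protein kinase C delta type (Homo sapiens), read by TR-FRET, with a stated time of 2 h (a lower number here means a stronger inhibitor, a higher number a weaker inhibitor), a value of 4500 nM. Compound 2 `CO[C@H]1CC[C@@H](CNc2cc(NCc3cnccc3C(F)(F)F)ncc2C#N)CC1` gives in this assay a value of 5000 nM, the higher of the two numbers, though its gap to compound 1 lies within the scatter, so the two read alike. Compound 3 `CC1(C)[C@H](Nc2cc(NCc3cnccc3C(F)(F)F)ncc2C#N)C[C@H]1C(N)=O` differs from compound 2 in one place: 3-carbamoyl-2,2-dimethylcyclobutyl in place of (4-methoxycyclohexyl)methyl on a nitrogen on an aromatic ring. Among the measured compounds shown here, no measured pair shows this change, so its effect is unknown. The expected step is a 1.3-fold lower number from compound 2 to compound 3 (0.10 log units; within the scatter), none beyond the scatter. Compound 3 is estimated at 4000 nM, ranging from 800 nM to 20000 nM.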

Compound 3, half-maximal inhibitory concentration: 900 nM
The estimate for compound 3 lay 4.4-fold (0.65 log units) above the measured number; the range from low to high includes it.
By their numbers in this assay, from the lowest: compound 3; then compounds 1 and 2 (each within the scatter of the next).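

In this assay, putting 3-carbamoyl-2,2-dimethylcyclobutyl in place of (4-methoxycyclohexyl)methyl on this nitrogen gives a 5.6-fold lower number from compound 2 to compound 3 (0.74 log units; beyond the scatter) and so shows that the number responds to the group held here. The swap alters several features together: the ring size, the methoxy for a carbamoyl, and the count of hydrogen-bond donors, so no single feature can be credited. Nothing measured here explains the step. Still open, going by these compounds, is whether the carbamoyl itself matters, which a carboxylic acid or an amine in its place would test. Also open, on these data alone, is what the cyclobutyl ring does without its two methyl groups.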